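This account rests on a few compounds, and the source may have more. Where it says the series, first, only, none or still open, it means among the compounds named here.

Working notes on the series in a functional assay on A549 cells (Homo sapiens) for cytotoxicity, read by MTT assay, with a stated time of 72 h; on this read-out higher numbers stand for weaker inhibition and lower numbers for stronger inhibition. Compound 1 (`COC(=O)c1sc2cc(OC)ccc2c1Nc1cc(OC)c(OC)c(OC)c1`) gives 8.5 nM and compound 3 (`COC(=O)c1sc2cc(C)ccc2c1Nc1cc(OC)c(OC)c(OC)c1`) gives 10.8 nM, so the two stand together. The measured step is a 1.3-fold higher number from compound 1 to compound 3 (0.10 log units; within the scatter), with methyl in place of methoxy on an aromatic carbon. Compound 2 (`CCOC(=O)c1sc2ccccc2c1Nc1cc(OC)c(OC)c(OC)c1`) gives 8530 nM, a far higher number than the other two.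

Compound 4 (`CCOC(=O)c1sc2cc(C)ccc2c1Nc1cc(OC)c(OC)c(OC)c1`) differs from compound 3 by methyl in place of hydrogen on a saturated chain carbon bound to an oxygen next to a carbonyl group, which reads methoxycarbonyl to ethoxycarbonyl. Going by the values given here, no measured step isolates this change. Among the compounds with values here, the one step available, a 1.3-fold higher number from compound 1 to compound 3 (0.10 log units; within the scatter), concerns a different place and gives no direct guide. Within the data shown here, the methyl on an aromatic carbon in compound 3 is absent from compound 2, the only measured compound with ethoxycarbonyl, so compound 2 at 8530 nM combines two differences and sets only a loose upper guide.

A higher number in this assay is therefore expected, beyond the scatter but well short of that whole gap. The expected change is a 5.6-fold higher number from compound 3 to compound 4 (0.74 log units; beyond the scatter). For compound 4 the estimated value is 60 nM, with an expected range of 12 nM to 500 nM.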

Compound 4, half-maximal inhibitory concentration: 7.2 nM
Compound 4: the middle estimate sits 8.3-fold (0.92 log units) above what was measured; the measured number lies below the stated range.
By their numbers in this assay, from the lowest: compounds 4, 1 and 3 (each within the scatter of the next); then compound 2.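

In this assay, lengthening methoxycarbonyl to ethoxycarbonyl, with methyl in place of hydrogen on a saturated chain carbon bound to an oxygen next to a carbonyl group, leaves the number within the scatter (a 1.5-fold lower number from compound 3 to compound 4 (0.18 log units; within the scatter)), so this position accepts the added methyl with the methyl on an aromatic carbon present. With ethoxycarbonyl held constant, methyl in place of hydrogen on an aromatic carbon brings a large step beyond the scatter (a 1200-fold lower number from compound 2 to compound 4 (3.07 log units; beyond the scatter)), which places the high number of compound 2 with that aromatic hydrogen and not with ethoxycarbonyl in this pair. No measurement given here offers an explanation for either step.

Going by these compounds, whether ethoxycarbonyl is equally accepted alongside the methoxy group of compound 1 remains open, as does the size of the same aromatic hydrogen-to-methyl step with methoxycarbonyl in place. Also open, on these data alone, is how this position responds to a longer chain such as propoxycarbonyl or to a carboxylic acid in place of the ester, and how the aromatic carbon responds to chlorine.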